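The source may hold more compounds than are shown below. What is called first, only, known or untested is meant among the compounds shown, and "the series" means these compounds.

Three close relatives share one core here. Compound 1 `Nc1nc(Cl)c2ncn(Cc3ccccc3CCl)c2n1` carries an amino group and gives 2950 nM in a functional assay on NCI-H522 cells (Homo sapiens) for cytotoxicity, read by sulforhodamine B assay, with a stated time of 48 h; on this read-out lower numbers stand for stronger inhibition of growth and higher numbers for weaker inhibition of growth. Its number is the second highest of the three, yet it sits within the scatter of both neighbours: compound 2 `ClCc1ccccc1Cn1cnc2ncnc(Cl)c21` gives 2810 nM, and compound 3 `Nc1nc(Cl)c2ncn(Cc3cccc(CCl)c3)c2n1` gives 3310 nM, so no order among the three can be read from these values. Compound 4 `ClCc1ccccc1Cn1cnc2c(Cl)ncnc21` has not been measured. Relative to compound 1 it changes in one place: hydrogen in place of amino on an aromatic carbon. Going by the values given here, no measured pair shows this exact change, so there is nothing to lean on beyond the tight cluster already seen. The step expected from this change is a 1.0-fold higher number from compound 1 to compound 4 (0.01 log units; within the scatter), that is, none beyond the scatter. Compound 4 is therefore estimated at 3000 nM, within a range from 1400 nM to 6500 nM.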

Compound 4, concentration for 50% growth inhibition: 1820 nM
Beside the measured number, compound 4's estimate is 1.6-fold (0.22 log units) above it; the measured number falls inside the stated range.
By their numbers in this assay, from the lowest: compounds 4, 2, 1 and 3 (each within the scatter of the next).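

Going by these compounds alone, replacing the amino group on the aromatic carbon between two ring nitrogen atoms with hydrogen gives a 1.6-fold lower number from compound 1 to compound 4 (0.21 log units; within the scatter) in this assay and offers the first direct reading of this position. Here, the amino group can go without a step beyond the scatter. Nothing measured here explains this result.

From the compounds shown here alone, whether a methylamino group, a hydroxyl group or a longer chain at this position would move the number beyond the scatter stays open. So does whether the same change would give a similar step starting from compound 3.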